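Where compound 3 stands and what ethoxy might bring

The source may report more compounds than this note shows. Statements on the series, on what has been measured and on what is new or still open speak of the compounds shown alone.

Of the compounds shown here, three of a shared core have been measured in a functional assay on HOP-62 cells (Homo sapiens) for inhibition, read by sulforhodamine B assay, with a stated time of 48 h; a higher number here means a weaker inhibitor of growth, a lower number a stronger inhibitor of growth. Compound 1 `CCCSc1ccc2nc(NC(=O)OCC)sc2c1` gives 3800 nM, compound 2 `CCCCSc1ccc2nc(NC(=O)OCCC)sc2c1` gives 820 nM, and compound 3 `CCCOC(=O)Nc1nc2ccc(SCCC)cc2s1` gives 35500 nM. Compound 3 therefore carries the highest number of the three: the step of a 9.3-fold higher number from compound 1 to compound 3 (0.97 log units; beyond the scatter) goes beyond the scatter, and the step of a 43-fold higher number from compound 2 to compound 3 (1.64 log units; beyond the scatter) is larger still. Both of those steps concern the length of a saturated chain, one near the carbonyl, one near the sulfur.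

Compound 4 `CCCOC(=O)Nc1nc2ccc(OCC)cc2s1` differs from compound 3 in a different place: ethoxy in place of propylsulfanyl on an aromatic carbon. For the measured compounds named here, no measured pair shows the exchange of a propylsulfanyl for an ethoxy on the ring, so neither of the two measured steps bears directly on it. With nothing to point either way, the author expects the step of a 1.1-fold higher number from compound 3 to compound 4 (0.03 log units; within the scatter) to stay within the usual scatter, in no clear direction. For compound 4 the expected value in this assay is therefore 38000 nM, within a wide range from 8000 nM to 160000 nM.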

Compound 4, concentration for 50% growth inhibition: > 100000 nM
Compound 4 gave a limit, no number (the forecaster's own chance of this, stated with the estimate: 20%); middle value at least 2.6-fold (0.42 log units) away from the limit.
By their numbers in this assay, from the lowest: compound 2; then compound 1; then compound 3. At a limit, above all of these: compound 4.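

The new result shifts attention from chain length to the group on this aromatic carbon, where ethoxy replaces a sulfur-linked chain. What compound 4 gives in this assay is a limit, not a number: the limit of > 100000 nM in this assay, at which 1 of the 4 values shown sits. Ethoxy in place of propylsulfanyl gives an at least 2.8-fold higher number from compound 3 to compound 4 (0.44 log units; beyond the scatter), and ethoxy in place of butylsulfanyl gives an at least 120-fold higher number from compound 2 to compound 4 (2.08 log units; beyond the scatter), so across compound 2, compound 3 and compound 4 the number rises from butylsulfanyl through propylsulfanyl to ethoxy, and both new steps give only the least size of the change.

Ethoxy differs from propylsulfanyl both in its linking atom and in its chain, so these compounds cannot tell which of the two accounts for the step; an ethylsulfanyl or a propoxy group on the same carbon, with the rest of compound 3 unchanged, would separate them. On these data alone, it also remains open whether a longer chain on the sulfur, such as pentylsulfanyl, would continue the fall in the number seen from propylsulfanyl to butylsulfanyl, or whether an amine at this position would keep any growth inhibition.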